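The source may report more compounds than this note shows. Statements on the series, on what has been measured and on what is new or still open speak of the compounds shown alone.

In a functional assay on MDA-MB-435 cells (Homo sapiens) for inhibition, read by sulforhodamine B assay, with a stated time of 48 h (a lower number here means a stronger inhibitor of growth, a higher number a weaker inhibitor of growth), compound 1 `COc1ccc(-c2[nH]c3ccccc3c2/C=C(\C#N)S(=O)(=O)c2ccccc2)cc1` gives 203 nM, and compound 2 `COc1ccc2[nH]c(-c3ccccc3)c(C=C(C#N)C#N)c2c1` gives 607 nM. Compound 3 `CC(=O)/C(=C\c1c(-c2ccccc2)[nH]c2ccccc12)S(=O)(=O)c1ccccc1`, which carries an acetyl on the double-bonded chain carbon, gives 295 nM in this assay and stands second highest of the three numbers; its value and that of compound 1 lie within the scatter of one another, while compound 2 gives the higher number by a margin beyond the scatter. Among the measured compounds shown here, compound 4 `O=C(/C(=C\c1c(-c2ccccc2)[nH]c2ccccc12)S(=O)(=O)c1ccccc1)c1ccccc1` differs from compound 3 by phenyl in place of methyl on a carbonyl carbon, a change with no measured counterpart in this set; neither compound 1 nor compound 2 speaks to it. Without a matching step, the expectation in this assay is a move of a 1.1-fold higher number from compound 3 to compound 4 (0.04 log units; within the scatter), in no preferred direction and not beyond the scatter. Compound 4 is accordingly estimated at 320 nM, with a range from 110 nM to 950 nM.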

Compound 4, concentration for 50% growth inhibition: 3900 nM
Compound 4: middle estimate off by 12-fold (1.09 log units), on the low side; measured number above the stated range.
By their numbers in this assay, from the lowest: compounds 1 and 3 (each within the scatter of the next); then compound 2; then compound 4.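

Replacing acetyl with benzoyl on the double-bonded chain carbon is far from a neutral change: in this assay the step reads a 13-fold higher number from compound 3 to compound 4 (1.12 log units; beyond the scatter), so the group on this carbonyl carbon strongly affects growth inhibition. Compound 1 and compound 2 carry no such carbonyl and could not show this. No available evidence bears on the reason for the size of this step.

Still open, as far as these compounds go, is whether the rise belongs to the phenyl ring itself or would also appear with a longer chain such as propyl or with an amine on the same carbonyl carbon.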